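Chain Ending Swapped: Sulfonyl in Place of a Benzyl

The compounds below may be only part of what the source reports. "The series", "measured", "known", "first", "only" and "open" are said of these compounds alone.

Compound 2 `CSc1ccccc1CCCCCCC(=O)c1ncc(-c2ccccn2)o1` inhibits the enzyme in an assay for inhibition of Fatty-acid amide hydrolase 1 (Rattus norvegicus) (on this read-out higher numbers stand for weaker inhibition and lower numbers for stronger inhibition), with 3.3 nM. Among the two compounds measured it carries the higher number, but its neighbour compound 1 `O=C(CCCCCCc1ccc(Cl)cc1)c1ncc(-c2ccccn2)o1` gives 2.7 nM, and the step of a 1.2-fold higher number from compound 1 to compound 2 (0.09 log units; within the scatter) lies within the scatter. Compound 3 `O=C(CCCCCS(=O)(=O)c1ccccc1)c1ncc(-c2ccccn2)o1` differs from compound 2 in one place: phenylsulfonyl in place of 2-(methylsulfanyl)benzyl on a saturated chain carbon, five bonds along the chain from a carbonyl carbon. Among the measured compounds shown here, the only measured step, from compound 1 to compound 2, exchanged one ring substituent for another and changed little; no measured step speaks to replacing a chain carbon by a sulfonyl. Compound 3 is therefore expected to show a modestly higher number, a 4.5-fold higher number from compound 2 to compound 3 (0.66 log units; beyond the scatter), with the estimate 15 nM in a range from 3 nM to 80 nM.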

Compound 3, inhibition constant: 6000 nM
Estimate against measurement, compound 3: 400-fold (2.60 log units) below, outside the stated range (above it).
By their numbers in this assay, from the lowest: compounds 1 and 2 (each within the scatter of the next); then compound 3.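

In this assay the end of this chain proves far less forgiving than the earlier ring swap suggested: phenylsulfonyl in place of 2-(methylsulfanyl)benzyl brings a 1800-fold higher number from compound 2 to compound 3 (3.26 log units; beyond the scatter) and phenylsulfonyl in place of 4-chlorobenzyl brings a 2200-fold higher number from compound 1 to compound 3 (3.35 log units; beyond the scatter) at the same place. Nothing measured here says why the number climbs so steeply. Open, as far as these compounds go, is whether the sulfonyl itself or the loss of the ring substituent drives the step; plain benzyl or phenylsulfanyl at this place would separate the two.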